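The source may hold more compounds than are shown below. What is called first, only, known or untested is meant among the compounds shown, and "the series" means these compounds.

Measured so far:
compound 1, `C[C@H](NC(=O)Nc1ccccc1F)c1ccccc1`: 65%
compound 2, `C[C@@H](NC(=O)Nc1cccc(F)c1)c1ccccc1`: 84%
compound 3, `C[C@H](NC(=O)Nc1cccc(F)c1F)c1ccccc1`: 100%

Three ureas have been run in an ADME assay on the whole organism with Oryza sativa as the target, tested at 10 uM; a lower number here means a stronger effect, a higher number a weaker effect of the compound at the concentration tested. Compound 1 gives 65% and stands lowest of the three, so its effect at the tested concentration is the strongest seen here. The core of compound 2 differs from that of compound 1 in a way that is not broken down here. Compound 2 gives 84%, a number beyond the scatter from compound 1. Compound 3 gives 100%, the highest of the set.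

One step between measured compounds is fluoro in place of hydrogen on an aromatic carbon. In this assay that step reads a number 35 percentage points higher from compound 1 to compound 3 (beyond the scatter), a large rise that weakens the effect at the tested concentration.

Compound 4, `C[C@@H](NC(=O)Nc1cc(F)ccc1F)c1ccccc1`, has not yet been measured. It is made from compound 2 by fluoro in place of hydrogen on an aromatic carbon, the same kind of change as that from compound 1 to compound 3, though around the place it differs: in compound 4 the new fluoro sits ortho to a large group and para to a fluoro group, whereas in compound 3 it sits ortho to a fluoro group and meta to a large group.

Going by the values given here, the only precedent for adding a fluoro to this ring is the step from compound 1 to compound 3, which lifted the number strongly. Because compound 2 already gives 84%, the room to rise is smaller than it was for compound 1. Compound 4 is therefore expected to rise by a number 11 percentage points higher from compound 2 to compound 4 (beyond the scatter), a smaller step than a number 35 percentage points higher from compound 1 to compound 3 (beyond the scatter), and its estimated value is 95%, between 82% and 100%.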

Compound 4, a percentage reported as activity, at one concentration (the size of the read-out at that concentration, not a potency): 92%
Beside the measured number, compound 4's estimate is 3 percentage points above it, and the stated range covers the measured number.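

In this assay, fluoro in place of hydrogen on an aromatic carbon does not read the same on the two cores: the same change on two cores in this assay, a number 35 percentage points higher (beyond the scatter) from compound 1 to compound 3 and a number 8 percentage points higher (within the scatter) from compound 2 to compound 4, 27 percentage points apart, beyond the scatter of two such steps The new step, a number 8 percentage points higher from compound 2 to compound 4 (within the scatter), cannot be told apart from no shift at all, so the large rise in a number 35 percentage points higher from compound 1 to compound 3 (beyond the scatter) did not carry over to the second core and cannot be treated as a fixed increment for this change across the series. What the pair does not show is the source of the gap, since the two steps differ both in the core and in where the new fluoro sits on the ring, and two steps cannot separate these or say how the change would read on any further core.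

The compounds shown leave open whether a different small group on the same ring, such as chloro or methoxy, would follow the fluoro steps or depart from them. They also leave open how the number in this assay would respond to an amine or a carboxylic acid on the other aromatic ring, which carries no substituent in any of the four compounds.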